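A few compounds are considered here, and "the series" means these few. Any claim that something is new, unique, unknown or untested is made for them only; others in the source may bear on it.

Measured so far in an assay on CHO cells for displacement of a labelled ligand from 5-hydroxytryptamine receptor 7 (Homo sapiens); a lower number here means a stronger inhibitor, a higher number a weaker inhibitor:
compound 1 `CCC1(CCCCN2CCN(c3cccc(OC)c3)CC2)C(=O)Nc2ccccc21`: 2.55 nM
compound 2 `CCC1(CCCCN2CCN(c3ccc(F)cc3)CC2)C(=O)Nc2ccccc21`: 0.43 nM

Among the compounds with values here, compound 2 stands lowest of the two numbers in this assay; its nearest neighbour is compound 1, the single measured step running a 5.9-fold lower number from compound 1 to compound 2 (0.77 log units; beyond the scatter). Compound 3 `CCC1(CCCCN2CCN(c3ccc(Cl)c(Cl)c3)CC2)C(=O)Nc2ccccc21` has not been measured. It differs from compound 2 as follows: 3,4-dichlorophenyl in place of 4-fluorophenyl on an amine nitrogen in a ring. Within the data shown here, no measured step bears directly on this change. Among the measured compounds shown here, the only step known, a 5.9-fold lower number from compound 1 to compound 2 (0.77 log units; beyond the scatter), exchanges 3-methoxyphenyl for 4-fluorophenyl on the same ring nitrogen and so sets no direction for a move from 4-fluorophenyl to 3,4-dichlorophenyl. With nothing to point either way, the expected step from compound 2 to compound 3 in this assay is a 1.4-fold higher number from compound 2 to compound 3 (0.14 log units; within the scatter), which is within the scatter. For compound 3 the estimate in this assay is 0.6 nM, with an expected range of 0.15 nM to 2.5 nM.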

Compound 3, inhibition constant: 0.63 nM
Compound 3: middle estimate off by 1.1-fold (0.02 log units), on the low side; measured number inside the range.
By their numbers in this assay, from the lowest: compounds 2 and 3 (each within the scatter of the next); then compound 1.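

On the amine nitrogen in the ring, in this assay, 3,4-dichlorophenyl and 4-fluorophenyl are not separated: the exchange gives a 1.5-fold higher number from compound 2 to compound 3 (0.17 log units; within the scatter), so two chlorines in place of one fluorine leave the number within the scatter. Within the data shown here, the second halogen-bearing group also stands clear of 3-methoxyphenyl, with a 4.0-fold lower number from compound 1 to compound 3 (0.61 log units; beyond the scatter), so both halogen-bearing compounds share the same direction relative to compound 1, the only methoxy compound of the three. No evidence at hand accounts for either step.

Still open, on these data alone, is whether the gap to compound 1 belongs to the methoxy group itself or to where it sits, a question that 4-methoxyphenyl or 3-chlorophenyl on the same nitrogen would address. Unsubstituted phenyl and pyridyl at this nitrogen, and a shorter or longer chain to the core, also remain open.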